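Cyclopropylamino to 4-Oxopiperidinyl: What the Known Step Suggests

The source may report more compounds than this note shows. Statements on the series, on what has been measured and on what is new or still open speak of the compounds shown alone.

Compound 1, `Nc1nc(-c2ccco2)nc2sc(CNC3CC3)cc12`: 1890 nM
Compound 2, `Nc1nc(-c2ccco2)nc2sc(CN3CCC(O)CC3)cc12`: 4000 nM

In an assay on CHO-K1 cells for antagonist activity at adenosine receptor A1 (Homo sapiens), read by a beta-galactosidase reporter, with stated times of 15 min and 6 h (a higher number here means a weaker inhibitor, a lower number a stronger inhibitor), compound 1 gives the lower of the two numbers. Within the data shown here, the only step measured so far, a 2.1-fold higher number from compound 1 to compound 2 (0.33 log units; beyond the scatter), is modest yet beyond the scatter. Compound 3, `Nc1nc(-c2ccco2)nc2sc(CN3CCC(=O)CC3)cc12`, differs from compound 1 in one place: 4-oxopiperidin-1-yl in place of cyclopropylamino on a saturated chain carbon bound to an aromatic carbon. Among the measured compounds shown here, the entering group resembles the one entering in that step, a six-membered ring with one hetero atom bound at the same place, so a similar weakening is expected, a 1.9-fold higher number from compound 1 to compound 3 (0.27 log units; within the scatter). Compound 3 is therefore estimated at 3500 nM, with a range from 1500 nM to 8000 nM.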

Compound 3, inhibition constant: 2720 nM
Estimate against measurement, compound 3: 1.3-fold (0.11 log units) above; the range from low to high includes it.
By their numbers in this assay, from the lowest: compounds 1, 3 and 2 (each within the scatter of the next, the first and the last beyond it).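

On a saturated chain carbon bound to an aromatic carbon, 4-oxopiperidin-1-yl cannot be told apart from cyclopropylamino in this assay, with a 1.4-fold higher number from compound 1 to compound 3 (0.16 log units; within the scatter). It also cannot be told apart from 4-hydroxypiperidin-1-yl, with a 1.5-fold lower number from compound 2 to compound 3 (0.17 log units; within the scatter), so the carbonyl and the hydroxyl on this ring read alike here. Nothing measured here says why these groups read alike. Still open, from the compounds shown here alone, is what the ring substituent contributes at all: plain piperidin-1-yl, with neither oxygen group, or morpholin-4-yl at this place would test that.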